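This account rests on a few compounds, and the source may have more. Where it says the series, first, only, none or still open, it means among the compounds named here.

Among the measured compounds shown here, compound 2 `C[C@@H]1CN(C(=O)C(=O)c2c[nH]c3c(-c4nccs4)ccnc23)CCN1C(=O)c1ccccc1` gives 41% in an ADME assay on the whole organism for pharmacokinetics, with Rattus norvegicus as the target, at a dose of 5 mg/kg by the oral route (a lower number here means that a smaller share of the oral dose reaches the circulation, a higher number that a larger share of the oral dose reaches the circulation), the lower of the two numbers known so far; compound 1 `C[C@@H]1CN(C(=O)C(=O)c2c[nH]c3c(-c4ncco4)ccnc23)CCN1C(=O)c1ccccc1` gives 60% in this assay. For the measured compounds named here, the only measured step is a number 19 percentage points lower from compound 1 to compound 2 (beyond the scatter), a change that swaps one five-membered aromatic group on the shared core for another. Compound 3 `C[C@@H]1CN(C(=O)C(=O)c2c[nH]c3c(-n4nccn4)ccnc23)CCN1C(=O)c1ccccc1` differs from compound 2 at that same place: 2H-1,2,3-triazol-2-yl in place of 1,3-thiazol-2-yl on an aromatic carbon. The measured step bears on this change in that it shows the group at this place can shift the oral bioavailability by a modest amount, yet it does not tell which way a third group will move it, since the groups involved are different. Going by the values given here, compound 3 is therefore expected to land between the two known numbers, at an estimated 50% in this assay, with a range from 25% to 75%. The step this estimate implies, a number 9 percentage points higher from compound 2 to compound 3 (within the scatter), is expected to stay within the usual scatter.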

Compound 3, oral bioavailability: 78%
The estimate for compound 3 lay 28 percentage points below the measured number, outside the stated range (above it).
By their numbers in this assay, from the lowest: compound 2; then compound 1; then compound 3.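

In this assay, the change to 2H-1,2,3-triazol-2-yl on this aromatic carbon gives a number 37 percentage points higher from compound 2 to compound 3 (beyond the scatter) and is a large step, so the group here can move the oral bioavailability further than the earlier pair showed. The same group also gives a number 18 percentage points higher from compound 1 to compound 3 (beyond the scatter) and so lifts the number past both five-membered rings with 2 hetero atoms, rather than leaving it within the span they set. The compounds shown offer no measured property that would account for this rise.

Among the compounds shown here, with only three groups at this place, it remains open whether the count of ring hetero atoms has any bearing on the number. Going by these compounds, how an amine, a carboxylic acid or a phenyl ring on this carbon would read in this assay also remains open.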